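Benzyl ester replacing tert-butyl in a thiophene thiourea

A few compounds are considered here, and "the series" means these few. Any claim that something is new, unique, unknown or untested is made for them only; others in the source may bear on it.

Of the compounds shown here, two have been tested in an assay on membranes from CHO cells for displacement of a labelled ligand from adenosine receptor A1 (Homo sapiens), read by scintillation counting, with a stated time of 60 min, tested at 1 uM; on this read-out lower numbers stand for less inhibition and higher numbers for more inhibition at the one concentration tested (going by the name of the read-out). Compound 1 `CC1=C(C(=O)OCc2ccccc2)C(c2ccco2)NC(=S)N1` gives 32% in this assay. Compound 2 `CC1=C(C(=O)OC(C)(C)C)C(c2cccs2)NC(=S)N1` gives 22%, the lower of the two numbers, yet the gap to compound 1 lies within the scatter. Compound 3 `CC1=C(C(=O)OCc2ccccc2)C(c2cccs2)NC(=S)N1` is not yet measured. It differs from compound 2 by benzyl in place of tert-butyl on an oxygen next to a carbonyl group. Among the compounds with values here, no step between measured compounds is known, so the expectation rests on the two numbers only: the shift from compound 2 to compound 3 is expected to be a number 6 percentage points higher from compound 2 to compound 3 (within the scatter), nothing beyond the scatter. Compound 3 is therefore estimated at 28%, with a range from 10% to 48%.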

Compound 3, a percentage reported as inhibition, at one concentration (the size of the read-out at that concentration, not a potency): 34%
Beside the measured number, compound 3's estimate is 6 percentage points below it; the measured number falls inside the stated range.
By their numbers in this assay, from the lowest: compounds 2, 1 and 3 (each within the scatter of the next, the first and the last beyond it).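

Within the data shown here, with thiophen-2-yl held in place, benzyl in place of tert-butyl on an oxygen next to a carbonyl group gives the first step at this position in this assay: a number 12 percentage points higher from compound 2 to compound 3 (beyond the scatter). With benzyl held in place, thiophen-2-yl in place of furan-2-yl on a saturated ring carbon gives a number 2 percentage points higher from compound 1 to compound 3 (within the scatter). Nothing available here accounts for either step.

Going by these compounds, whether an ethyl ester, a substituted benzyl ester or a carboxylic acid would follow benzyl or tert-butyl remains open. Also open, on these data alone, is whether the benzyl step holds with furan-2-yl, and the single concentration gives no potency.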